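Methoxy to Dimethylamino: an Expected Step for Compound 4

A few compounds are considered here, and "the series" means these few. Any claim that something is new, unique, unknown or untested is made for them only; others in the source may bear on it.

Compound 1 `COc1ccc(C(=O)N(CCC(=O)NCc2ccccc2)Cc2ccc(C(=O)NO)cc2)cc1` gives 3490 nM in a functional assay on G55T2 cells (Homo sapiens) for antiproliferative activity, read by WST assay, with a stated time of 72 h; a higher number here means a weaker inhibitor, a lower number a stronger inhibitor.
Compound 2 `Cc1ccc(NC(=O)CCN(Cc2ccc(C(=O)NO)cc2)C(=O)c2ccc(N(C)C)cc2)cc1` gives 330 nM in this assay.
Compound 3 `Cc1ccc(C(=O)N(CCC(=O)NCc2ccccc2)Cc2ccc(C(=O)NO)cc2)cc1` gives 690 nM in this assay.

Of these three numbers, compound 1 holds the highest. The unmeasured compound 4 `CN(C)c1ccc(C(=O)N(CCC(=O)NCc2ccccc2)Cc2ccc(C(=O)NO)cc2)cc1` differs from compound 1 in one place: dimethylamino in place of methoxy on an aromatic carbon. For the measured compounds named here, the one measured step at this position, methyl in place of methoxy, gave a 5.1-fold lower number from compound 1 to compound 3 (0.70 log units; beyond the scatter). Going by the values given here, compound 2 carries a dimethylamino group but also a different amide, so its value shows only that a dimethylamino compound can sit well below compound 1. On this basis a lower number is expected for compound 4, a step of about a 5.0-fold lower number from compound 1 to compound 4 (0.70 log units; beyond the scatter). The estimate for compound 4 is 700 nM, within 250 nM to 2000 nM.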

Compound 4, half-maximal inhibitory concentration: 1150 nM
The estimate for compound 4 lay 1.6-fold (0.22 log units) below the measured number; the range from low to high includes it.
By their numbers in this assay, from the lowest: compound 2; then compounds 3 and 4 (each within the scatter of the next); then compound 1.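

In this assay, dimethylamino joins methyl as a second replacement that lowers the number from methoxy (a 3.0-fold lower number from compound 1 to compound 4 (0.48 log units; beyond the scatter)), while the two replacements themselves stay unseparated (a 1.7-fold higher number from compound 3 to compound 4 (0.22 log units; within the scatter)). With dimethylamino held fixed, the group on the amide-type nitrogen also matters (a 3.5-fold higher number from compound 2 to compound 4 (0.54 log units; beyond the scatter)). No measurement shown explains these steps.

The compounds shown leave open whether an amine, a carboxylic acid or a longer chain at this position would also lower the number from methoxy. On these data alone, whether benzyl and 4-methylphenyl would differ in the same way with methoxy or methyl on the ring also remains open.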